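A few compounds are considered here, and "the series" means these few. Any claim that something is new, unique, unknown or untested is made for them only; others in the source may bear on it.

Compounds measured in a functional assay on L1210 cells (Mus musculus) for cytotoxicity, read by MTT assay, with a stated time of 48 h; a higher number here means a weaker inhibitor, a lower number a stronger inhibitor: compound 1 `C=C1C(=O)O[C@H](C)[C@@H]1c1ccc([N+](=O)[O-])cc1`, 1900 nM; compound 2 `C=C1C(=O)O[C@H](C)[C@@H]1c1ccc(Br)cc1`, 7800 nM.

Within the data shown here, compound 2 holds the highest number of the two; its nearest neighbour is compound 1, and the step of a 4.1-fold higher number from compound 1 to compound 2 (0.61 log units; beyond the scatter) is the only measured step bearing on the aromatic substituent. Compound 3 `C=C1C(=O)O[C@H](C)[C@@H]1c1ccc(OC)cc1` differs from compound 2 by methoxy in place of bromo on an aromatic carbon. That single step shows the substituent on that carbon can move this assay modestly, yet gives no anchor for a methoxy group. Compound 3 is therefore expected to stand near compound 2, perhaps somewhat weaker, with a step of a 1.3-fold higher number from compound 2 to compound 3 (0.11 log units; within the scatter), and an estimated value of 10000 nM, within 3000 nM to 30000 nM.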

Compound 3, half-maximal inhibitory concentration: 4400 nM
Beside the measured number, compound 3's estimate is 2.3-fold (0.36 log units) above it; low and high end bracket the measured number.
By their numbers in this assay, from the lowest: compound 1; then compounds 3 and 2 (each within the scatter of the next).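

With methoxy in place of bromo in this assay, the change is a 1.8-fold lower number from compound 2 to compound 3 (0.25 log units; within the scatter) and so does not separate these two groups on this aromatic carbon, even though methoxy brings a hydrogen-bond acceptor and bromo does not. Methoxy in place of nitro gives a 2.3-fold higher number from compound 1 to compound 3 (0.36 log units; beyond the scatter) and so sets the nitro group of compound 1 apart from a second group as well as from bromo. No evidence here accounts for either step. Still open, on these data alone, is whether an amine or a carboxylic acid on this carbon would stand with compound 1 or with compound 2 and compound 3.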